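Benzyloxy on the Aryl Ring and Microsomal Stability

The compounds below may be only part of what the source reports. "The series", "measured", "known", "first", "only" and "open" are said of these compounds alone.

The study compares four compounds in an ADME assay on microsomes from liver (Rattus norvegicus, strain Sprague-Dawley) for metabolic stability, read by LC-MS, with a stated time of 15 min, tested at 20 uM; on this read-out lower numbers stand for a less stable compound and higher numbers for a more stable compound. Compound 1 `O=C(OCc1ccccc1)[C@@H]1COC(c2ccccc2)=N1` and compound 2 `O=C(OCc1ccccc1)c1coc(-c2ccccc2)n1` share an ester and a phenyl-bearing heterocycle, but how their two cores differ is not broken down here. In this assay compound 1 gives 2.8%, and compound 2 gives 2.7%. Compound 3 `O=C(OCc1ccccc1)c1coc(-c2ccccc2OCc2ccccc2)n1` carries benzyloxy in place of hydrogen on an aromatic carbon relative to compound 2, and in this assay compound 3 gives 3.5%, so that a number 0.8 percentage points higher from compound 2 to compound 3 (within the scatter). Compound 4 `O=C(OCc1ccccc1)[C@@H]1COC(c2ccccc2OCc2ccccc2)=N1` carries the same change on the core of compound 1, namely (benzyloxy in place of hydrogen on an aromatic carbon). Because a number 0.8 percentage points higher from compound 2 to compound 3 (within the scatter), the corresponding step is expected to be about a number 0.7 percentage points higher from compound 1 to compound 4 (within the scatter). Compound 4 is therefore estimated to give about 3.5% in this assay, with a plausible range from 0% to 12%.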

Compound 4, percent of the compound remaining in the Rattus norvegicus assay: 5.2%
Estimate against measurement, compound 4: 1.7 percentage points below; the range from low to high includes it.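

In the Rattus norvegicus assay compound 1 gives 2.8% and compound 4 gives 5.2%. In the Rattus norvegicus assay the new step reads a number 2.4 percentage points higher from compound 1 to compound 4 (within the scatter), and it agrees with the earlier one: the same change on two cores in the Rattus norvegicus assay, a number 0.8 percentage points higher (within the scatter) from compound 2 to compound 3 and a number 2.4 percentage points higher (within the scatter) from compound 1 to compound 4, 1.6 percentage points apart, within the scatter of two such steps. In a physicochemical assay for metabolic stability, read by LC-MS, in simulated gastric fluid, with a stated time of 15 min, tested at 50 uM (a lower number here means that less of the compound is left, a higher number that more of the compound is left), compound 1 gives 1.7% and compound 4 gives 0.8%. In the physicochemical assay the same change reads a number 0.9 percentage points lower from compound 1 to compound 4 (within the scatter), so neither assay separates compound 4 from compound 1. This shows that benzyloxy in place of hydrogen carries from one core to the other without a discernible difference between the two steps, but it does not show that the group alters stability on either core, since every step lies within the scatter.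

The compounds shown leave open whether a methoxy or an amine at the same place would behave alike. They also leave open whether an amide in place of the benzyl ester would change these numbers on either core.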